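The source may report more compounds than this note shows. Statements on the series, on what has been measured and on what is new or still open speak of the compounds shown alone.

Working notes on the series. Compound 1 `C[C@@H](Cn1ccc(-c2ccc(C#N)c(Cl)c2)n1)NC(=O)C1CC(=O)C1`, compound 2 `CC(=O)c1ccc(S(=O)(=O)N[C@@H](C)Cn2ccc(-c3ccc(C#N)c(Cl)c3)n2)cc1` and compound 3 `C[C@@H](Cn1ccc(-c2ccc(C#N)c(Cl)c2)n1)NS(=O)(=O)c1cccnc1` share one core and differ only in what sits on the amine nitrogen. In a functional assay on LNCaP cells (Homo sapiens) for antiproliferative activity, read by CCK-8 assay, with a stated time of 6 days (on this read-out higher numbers stand for weaker inhibition and lower numbers for stronger inhibition), compound 1 gives 3040 nM, compound 2 gives 5230 nM and compound 3 gives 6140 nM. Compound 3 carries the highest number of the three, though its gap to compound 2 is within the scatter and only the gap to compound 1 is beyond it. The two steps leading to compound 3 are a 2.0-fold higher number from compound 1 to compound 3 (0.31 log units; beyond the scatter) and a 1.2-fold higher number from compound 2 to compound 3 (0.07 log units; within the scatter).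

Compound 4 `C[C@@H](Cn1ccc(-c2ccc(C#N)c(Cl)c2)n1)Nc1cccnc1` is not yet measured. Relative to compound 3 the change is pyridin-3-yl in place of (pyridin-3-yl)sulfonyl on an amine nitrogen. Among the measured compounds shown here, of the measured steps, only the one from compound 1 to compound 3 exchanges a carbonyl-linked group for a sulfonyl-linked one, and it was modest; the step from compound 2 to compound 3 shows that swapping the aryl on the sulfonyl made no difference beyond the scatter. For the measured compounds named here, neither step removes the sulfonyl altogether, so no direct precedent exists. A step of at most modest size in this assay is therefore expected, with no firm direction, and the number for compound 4 is expected to lie near those of the measured compounds. The estimate for compound 4 in this assay is 5000 nM, with a range from 1500 nM to 16000 nM. The expected step is a 1.2-fold lower number from compound 3 to compound 4 (0.09 log units; within the scatter).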

Compound 4, half-maximal inhibitory concentration: 430 nM
For compound 4 the middle estimate is 12-fold (1.07 log units) above the measured one, and the stated range ends above it.
By their numbers in this assay, from the lowest: compound 4; then compounds 1, 2 and 3 (each within the scatter of the next, the first and the last beyond it).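

In this assay, among the compounds shown here, the amine nitrogen of the shared core proves far more sensitive to its linking group than the earlier compounds suggested: removing only the sulfonyl and keeping the pyridin-3-yl gives a 14-fold lower number from compound 3 to compound 4 (1.15 log units; beyond the scatter) in this series. The carbonyl-linked group is also surpassed, with a 7.1-fold lower number from compound 1 to compound 4 (0.85 log units; beyond the scatter) on the same nitrogen, so a pyridin-3-yl attached directly to it gives a lower number than the carbonyl and sulfonyl groups shown. The earlier compounds shown here stayed within a narrow band and gave no sign of a step this large, which suggests that the earlier exchanges among linked groups had not touched what matters most at this place. No measurement at hand bears on the cause of this step.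

The compounds shown leave open whether the gain belongs to the direct attachment of any aromatic ring or to pyridin-3-yl in particular, which a plain phenyl or a pyridin-4-yl on the same nitrogen would test. They also leave open how far the ring can move from the nitrogen, as a pyridin-3-ylmethyl group would show, and whether a simple alkyl chain there could do as well.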